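Series notes: compound 2 to compound 3

A few compounds are considered here, and "the series" means these few. Any claim that something is new, unique, unknown or untested is made for them only; others in the source may bear on it.

Compound 1 `C=C[C@@](C)(/C=C/c1ccc(OC)cc1)CCC=C(C)C` gives > 43400 nM (a limit)
Compound 2 `C=C[C@@](C)(/C=C/c1ccc(Nc2cc(F)c(F)cc2F)cc1)CCC=C(C)C` gives > 43400 nM (a limit)

Both entries come from a functional assay on NALM-6 cells (Homo sapiens) for cytotoxicity, with a stated time of 72 h (on this read-out lower numbers stand for an effect already at smaller amounts and higher numbers for an effect only at larger amounts of compound), and neither is a number. Compound 2 reads > 43400 nM which is a limit. Within the data shown here, its standing is simply this shared ceiling (the limit of > 43400 nM in this assay, at which 2 of the 2 values shown sit) and no measured step exists. Compound 3 `C=C[C@@](C)(/C=C/c1ccc(Nc2ccc(Cl)c(Cl)c2)cc1)CCC=C(C)C` differs in one place: 3,4-dichlorophenyl in place of 2,4,5-trifluorophenyl on a nitrogen on an aromatic ring. The expected step (an at least 1.4-fold lower number from compound 2 to compound 3 (0.16 log units; that floor lies within the scatter)) is small and towards lower numbers, and another limit remains quite possible. Compound 3 is estimated at 30000 nM with a range from 8000 nM to 60000 nM expected.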

Compound 3, half-maximal effective concentration: > 43400 nM
Compound 3 ended at the assay's limit (the forecaster's own chance of this, stated with the estimate: 55%); at least 1.4-fold (0.16 log units) between middle value and limit.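

No step can be read from compound 1 or compound 2 to compound 3 in this assay since all three values are limits: the limit of > 43400 nM in this assay, at which 3 of the 3 values shown sit.

The compounds shown leave open whether any of these groups changes cytotoxicity in this series.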